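The compounds below may be only part of what the source reports. "The series", "measured", "known", "first", "only" and "open" are said of these compounds alone.

Measured so far: compound 1 `N=C(N)N1CCCC(Cc2cccc3ccoc23)C1` gives 2500 nM in an assay on cells for inhibition of Polycomb protein EED (Homo sapiens), read by ELISA, with a stated time of 48 h; on this read-out lower numbers stand for stronger inhibition and higher numbers for weaker inhibition; compound 2 `N=C(N)N1CCCC(Cc2cccc3occc23)C1` gives 2500 nM; for compound 3 `CC(C)c1nc(N)n2c1CCC(Cc1ccccc1F)C2` the entry reads "not determined" (no result reported), so no number is reported.

Compound 3 therefore stands nowhere on the numbers: no value in this assay exists for it, and the two values that do exist belong to compounds 1 and 2, which share a different core and so say nothing directly about compound 3. Compound 4 `COc1ccc(F)c(CC2CCc3c(C(C)C)nc(N)n3C2)c1` differs from compound 3 by methoxy in place of hydrogen on an aromatic carbon. Going by the values given here, no measured pair shows this change, so neither its size nor its direction can be read from the data. In this assay compound 4 is estimated to fall near 2000 nM, with an expected range from 300 nM to 15000 nM.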

Compound 4, half-maximal inhibitory concentration: 2900 nM
Compound 4: middle estimate off by 1.5-fold (0.16 log units), on the low side; the measured number falls inside the stated range.
By their numbers in this assay, from the lowest: compounds 1, 2 and 4 (each within the scatter of the next).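

No step can be read from compound 4: compound 3 offers no number to set against it, and compounds 1 and 2 differ from it in more than one place. What the methoxy group does to the read-out stays open, and no evidence on hand accounts for the value of compound 4.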